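The source may report more compounds than this note shows. Statements on the series, on what has been measured and on what is new or still open speak of the compounds shown alone.

Working notes on the series, all read in a functional assay on K562 cells (Homo sapiens) for cytotoxicity, read by MTT assay, with a stated time of 48 h; on this read-out lower numbers stand for stronger inhibition and higher numbers for weaker inhibition. Compound 1 (`Nc1ccccc1Nc1n[n+]([O-])c2ccccc2[n+]1[O-]`) gives 10600 nM, compound 2 (`COc1ccc(Nc2n[n+]([O-])c3ccccc3[n+]2[O-])cc1`) gives 2900 nM and compound 3 (`[O-][n+]1nc(NC2CC2)[n+]([O-])c2ccccc21`) gives 6600 nM. Compound 3 holds the second highest of the three numbers. Its value lies within the usual scatter of the value of compound 1, while compound 2 has a lower number, beyond the scatter.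

Compound 4 (`C=CCNc1n[n+]([O-])c2ccccc2[n+]1[O-]`) is the next to be read, and its difference from compound 3 is as follows: allyl in place of cyclopropyl on a nitrogen on an aromatic ring. In words, this is allyl in place of cyclopropyl on a nitrogen on an aromatic ring. Going by the values given here, no two measured compounds differ in one place only, so the series gives no direct precedent for this change. The measured numbers run only from compound 2 at 2900 nM to compound 1 at 10600 nM, so no step beyond the scatter is expected in this assay. The expected step is small, a 1.1-fold lower number from compound 3 to compound 4 (0.04 log units; within the scatter). For compound 4 the estimated value is 6000 nM, with an expected range of 2700 nM to 13000 nM.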

Compound 4, half-maximal inhibitory concentration: 11200 nM
Compound 4: the middle estimate sits 1.9-fold (0.27 log units) below what was measured, within the range that was stated.
By their numbers in this assay, from the lowest: compound 2; then compounds 3, 1 and 4 (each within the scatter of the next).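

Going by these compounds alone, compound 3 and compound 4 form the first pair that differs in one place only, with the same atoms joined differently. In this assay, cyclopropylamino to allylamino gives a 1.7-fold higher number from compound 3 to compound 4 (0.23 log units; within the scatter), so on a nitrogen on an aromatic ring, this read-out does not separate the closed three-membered ring from the open chain with its double bond. Nothing available bears on why the two groups read alike.

A single pair cannot show whether this holds for other groups on that nitrogen, such as a saturated propyl chain, a longer chain, or a chain ending in a carboxylic acid or an amine. It also cannot show whether the same change on a different core would read alike.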